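This account rests on a few compounds, and the source may have more. Where it says the series, first, only, none or still open, it means among the compounds named here.

Measured so far:
- compound 1, `O=C(/C(=C\c1ccc2ccccc2n1)SCc1ccc(F)cc1)c1ccc(Br)cc1`: 25000 nM
- compound 2, `O=C(/C(=C\c1ccc([N+](=O)[O-])c(O)c1)Sc1ccc(Br)cc1)c1c(F)c(F)c(F)c(F)c1F`: 1000 nM

In a functional assay on DU-145 cells (Homo sapiens) for inhibition, read by trypan blue exclusion, with a stated time of 96 h (on this read-out higher numbers stand for weaker inhibition of growth and lower numbers for stronger inhibition of growth), compound 1 gives the highest of the two numbers; compound 2 sits a good deal lower, and this gap lies beyond the scatter. The two differ in several places, so no single change accounts for it. Compound 3, `Cc1cc(C)cc(/C=C(/SCc2ccc(F)cc2)C(=O)c2ccc(Br)cc2)c1`, is not yet measured. It differs from compound 1 by 3,5-dimethylphenyl in place of quinolin-2-yl on a double-bonded chain carbon bound to a double-bonded chain carbon. Among the measured compounds shown here, no measured pair shows this change, so the step of a 1.7-fold lower number from compound 1 to compound 3 (0.22 log units; within the scatter) is expected to be small and downward, within the scatter. Compound 3 is estimated at 15000 nM, in the range 4000 nM to 50000 nM.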

Compound 3, concentration for 50% growth inhibition: 10000 nM
Compound 3: middle estimate off by 1.5-fold (0.18 log units), on the high side, within the range that was stated.
By their numbers in this assay, from the lowest: compound 2; then compound 3; then compound 1.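

In this assay, among the compounds shown here, the swap of quinolin-2-yl for 3,5-dimethylphenyl on a double-bonded chain carbon bound to a double-bonded chain carbon gives a 2.5-fold lower number from compound 1 to compound 3 (0.40 log units; beyond the scatter) as the first single-place comparison. At this place, neither the ring nitrogen nor the second aromatic ring of quinolin-2-yl is needed for growth inhibition in compound 3. No measured property bears on this step.

As far as these compounds go, whether pyridin-2-yl or an aminophenyl group at this place would move the number the same way remains open. So does whether the step carries over to the other groups of compound 2.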